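The source may hold more compounds than are shown below. What is called first, only, known or untested is meant among the compounds shown, and "the series" means these compounds.

Working notes on the series.

Three compounds share the same core and have been run in a functional assay on isolated protein for agonist activity at Glucose-dependent insulinotropic receptor (Rattus norvegicus), read by HTRF and cAMP accumulation; on this read-out higher numbers stand for larger maximal responses and lower numbers for smaller maximal responses. Compound 1 `CC(C)(C)OC(=O)N1CCC(O[C@H]2CC[C@H](Oc3ccc(S(C)(=O)=O)cc3F)CC2)CC1` gives 119%. Compound 2 `CC(C)OC(=O)N1CCC(O[C@H]2CC[C@H](Oc3ccc(S(C)(=O)=O)nc3)CC2)CC1` gives 125%. Compound 3 `C[C@@H](CF)OC(=O)N1CCC(O[C@H]2CC[C@H](Oc3cnc(S(C)(=O)=O)cn3)CC2)CC1` gives 123%. The three values lie close together: the gap from compound 3 to compound 2 and the gap from compound 3 to compound 1 are both within the usual scatter, so the three compounds cannot be told apart on maximal response, and no ordering among them is claimed.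

Compound 4 `CS(=O)(=O)c1cnc(O[C@H]2CC[C@H](OC3CCN(CC4(C(F)(F)F)CCC4)CC3)CC2)cn1` is not yet measured in this assay. The change from compound 3 is this: a group of 9 heavy atoms (6 carbon, 3 fluorine; one four-membered non-aromatic ring of carbon only) in place of a group of 7 heavy atoms (4 carbon, 2 oxygen, 1 fluorine; no ring), on an amine nitrogen in a ring. The carbamate unit on the amine nitrogen in the ring is thus replaced by the (1-(trifluoromethyl)cyclobutyl)methyl group.

For the measured compounds named here, no step between measured compounds bears on this change, since the three measured compounds vary only at the other end of the core. The three measured responses are all of similar size, so compound 4 is expected to give a response of the same order, with a step of a number 5 percentage points lower from compound 3 to compound 4 (within the scatter) that is expected to stay within the scatter, in either direction. The estimate for compound 4 in this assay is 118%, in the range 100% to 135%.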

Compound 4, largest response reached (Emax), in percent of the reference or control that the assay uses: 99%
Estimate against measurement, compound 4: 19 percentage points above; measured number below the stated range.
By their numbers in this assay, from the lowest: compound 4; then compounds 1, 3 and 2 (each within the scatter of the next).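

In this assay, for the compounds shown here, the group on the amine nitrogen in the ring affects maximal response in a way the earlier compounds could not show, with a number 24 percentage points lower from compound 3 to compound 4 (beyond the scatter) when the (1-(trifluoromethyl)cyclobutyl)methyl group takes the place of the carbamate unit. Without that unit compound 4 still reaches 99% in this assay, so a carbamate on this nitrogen is not a condition for an agonist response, and the loss is a modest one. No measurement at hand explains the lower response, so the step stands as an observation on this single pair.

The change swaps several features at once: the carbonyl and ester oxygen leave, while the four-membered carbon ring and the trifluoromethyl group enter, so the step cannot be assigned to any one of them. A plain cyclobutylmethyl group on the same nitrogen would separate the contribution of the trifluoromethyl group from that of the ring, and an amide or a urea there would show whether the response in this assay follows the carbonyl.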